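A Trifluoromethyl Swap in a Two-Compound Series

A few compounds are considered here, and "the series" means these few. Any claim that something is new, unique, unknown or untested is made for them only; others in the source may bear on it.

Of the compounds shown here, two sharing one core have been measured in a functional assay on AGS cells (Homo sapiens) for inhibition, read by MTT assay, with a stated time of 72 h; on this read-out lower numbers stand for stronger inhibition and higher numbers for weaker inhibition. Compound 1 `Cc1ccc(N2CCCC2)c(C(=O)Nc2ccc(CNC(=O)OCc3cccnc3)cc2)c1` gives 24700 nM, and compound 2 `COc1ccc(N2CCCC2)c(C(=O)Nc2ccc(CNC(=O)OCc3cccnc3)cc2)c1` gives 25600 nM. Among the measured compounds shown here, these two numbers lie within the scatter of each other, so compound 2 cannot be separated from its only neighbour.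

Compound 3 `O=C(NCc1ccc(NC(=O)c2cc(C(F)(F)F)ccc2N2CCCC2)cc1)OCc1cccnc1` changes one place in compound 2: trifluoromethyl in place of methoxy on an aromatic carbon. In words, trifluoromethyl stands in place of methoxy on an aromatic carbon, para to a pyrrolidin-1-yl group.

For the measured compounds named here, only one measured step bears on this, and it involves the same carbon: a 1.0-fold higher number from compound 1 to compound 2 (0.02 log units; within the scatter). It replaced methyl with methoxy and stayed within the scatter, but it never tested trifluoromethyl. No step beyond the scatter is therefore expected in this assay, though this rests on thin evidence. The expected change is a 1.2-fold lower number from compound 2 to compound 3 (0.07 log units; within the scatter). Compound 3 is estimated at 22000 nM, with an expected range of 9000 nM to 50000 nM.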

Compound 3, half-maximal inhibitory concentration: > 100000 nM
Compound 3: only a limit was reported; the forecaster's own chance of this, stated with the estimate: 15%; middle value at least 4.5-fold (0.65 log units) from the limit.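

In this assay compound 3 gives > 100000 nM, which is a limit and not a number. This carbon, para to a pyrrolidin-1-yl group, is therefore not indifferent to what it carries: methyl and methoxy could not be told apart there, yet trifluoromethyl in place of methoxy gives an at least 3.9-fold higher number from compound 2 to compound 3 (0.59 log units; beyond the scatter), and trifluoromethyl in place of methyl gives an at least 4.0-fold higher number from compound 1 to compound 3 (0.60 log units; beyond the scatter). Both steps point to weaker inhibition, but their full size stays unknown, and compound 3 is the only compound shown that reads as a limit: the limit of > 100000 nM in this assay, at which 1 of the 3 values shown sits.

The compounds shown leave open whether this loss is particular to trifluoromethyl or would also appear with a chlorine atom, a nitrile or an amine on the same carbon. They also leave open how far the number for compound 3 lies beyond its limit.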